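Notes on the sulfonyl substituent in this series

The source may report more compounds than this note shows. Statements on the series, on what has been measured and on what is new or still open speak of the compounds shown alone.

Measured so far:
compound 1, `Cc1ccc(S(=O)(=O)Cc2ccccc2)cc1C#Cc1cc(Cl)ccc1OCC(=O)O`, 5 nM
compound 2, `CS(=O)(=O)c1cncc(C#Cc2cc(Cl)ccc2OCC(=O)O)c1`, 60 nM

In an assay on CHO cells for displacement of a labelled ligand from prostaglandin D2 receptor 2 (Homo sapiens), read by scintillation counting (a lower number here means a stronger inhibitor, a higher number a weaker inhibitor), compound 1 gives 5 nM, the lowest of the two numbers shown. Compound 2 gives 60 nM, a higher number, and the gap between the two lies beyond the scatter. For the measured compounds named here, compound 2 differs from compound 1 in more than one place, so no single step between them can be counted from these two values alone.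

Compound 3, `CNS(=O)(=O)c1ccc(C)c(C#Cc2cc(Cl)ccc2OCC(=O)O)c1`, is not yet measured. It differs from compound 1 in one place: methylamino in place of benzyl on a sulfonyl sulfur. Going by the values given here, no measured pair shows this particular change, so its effect cannot be read from the present data. The expected step is a 4.0-fold higher number from compound 1 to compound 3 (0.60 log units; beyond the scatter), a loss beyond the scatter. Compound 3 is accordingly estimated at 20 nM, with a range from 6 nM to 70 nM.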

Compound 3, inhibition constant: 10 nM
Beside the measured number, compound 3's estimate is 2.0-fold (0.30 log units) above it, and the stated range covers the measured number.
By their numbers in this assay, from the lowest: compounds 1 and 3 (each within the scatter of the next); then compound 2.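

In this assay, methylamino in place of benzyl on a sulfonyl sulfur gives a 2.0-fold higher number from compound 1 to compound 3 (0.30 log units; within the scatter), so the two numbers cannot be told apart. At this position, then, a group with one six-membered aromatic ring and a group with no ring and one hydrogen-bond donor are both compatible with a number in this range, and the benzyl ring is not needed to reach it. No measurement shown gives a reason for this result.

For the compounds shown here, compound 2 differs from compound 3 in more than one place, so no step can be read between them, and the single pair does not separate the loss of the ring from the entry of the nitrogen. Still open, on these data alone, are an unsubstituted amino group, dimethylamino, morpholine and a longer chain ending in a carboxylic acid on the same sulfur.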